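This account rests on a few compounds, and the source may have more. Where it says the series, first, only, none or still open, it means among the compounds named here.

Working notes on the series.

Compound 2 `CC[C@@H]1C(=O)N(C)c2cnc(Nc3ccc(S(N)(=O)=O)cc3)nc2N1C1CCCC1` and compound 1 `CC[C@@H]1C(=O)N(C)c2cnc(Nc3ccc(S(=O)(=O)NCCCO)cc3)nc2N1C1CCCC1` share one core; compound 3 `CCC1C(=O)N(C)c2cnc(Nc3ccc(S(N)(=O)=O)cc3)nc2N1c1ccn(C)n1` and compound 4 `CCC1C(=O)N(C)c2cnc(Nc3ccc(S(=O)(=O)NCCCO)cc3)nc2N1c1ccn(C)n1` share another. The difference between the two cores is not broken down here. In a functional assay on NCI-H1975 cells (Homo sapiens) for antiproliferative activity, read by CCK-8 assay, with a stated time of 72 h (a higher number here means a weaker inhibitor of growth, a lower number a stronger inhibitor of growth), compound 2 gives 5290 nM, and compound 1 gives 2140 nM; the step of a 2.5-fold lower number from compound 2 to compound 1 (0.39 log units; beyond the scatter) belongs to the change (3-hydroxypropyl in place of hydrogen on a sulfonamide nitrogen). In this assay compound 3 gives "not active" (no number reported), with no number reported. Compound 4 carries the same change, (3-hydroxypropyl in place of hydrogen on a sulfonamide nitrogen), on the second core. Since compound 3 gave no number in this assay, and the comparable step from compound 2 to compound 1 was only a 2.5-fold lower number from compound 2 to compound 1 (0.39 log units; beyond the scatter), a shift of similar modest size is expected and compound 4 is expected to stay weak. Compound 4 is therefore estimated at 20000 nM in this assay, within 6000 nM to 60000 nM.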

Compound 4, concentration for 50% growth inhibition: 25800 nM
The estimate for compound 4 lay 1.3-fold (0.11 log units) below the measured number; the range from low to high includes it.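

In this assay, for the compounds shown here, compound 3 has no number, so no step to compound 4 can be read. As far as these compounds go, whether 3-hydroxypropyl on the sulfonamide nitrogen shifts growth inhibition on this core as it does from compound 2 to compound 1 stays open. No evidence on a cause is available here.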